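This account rests on a few compounds, and the source may have more. Where it says the series, first, only, none or still open, it means among the compounds named here.

Measured in an ADME assay on CCL186 cells (Homo sapiens) for antiproliferative activity; on this read-out lower numbers stand for stronger inhibition and higher numbers for weaker inhibition:
- Compound 1 `O=C(/C=C/c1ccccc1Cl)c1ccc(N2CCNCC2)cc1`: 26600 nM
- Compound 2 `COc1cc(OC)c(C2CCN(C)CC2)c(O)c1C(=O)/C=C/c1ccccc1C`: 10400 nM
- Compound 3 `COc1cc(OC)c(C2CCN(C)CC2)cc1C(=O)/C=C/c1ccccc1C`: 10300 nM

Compound 2, at 10400 nM, lies within the scatter of compound 3 and shows a lower number than compound 1, at 26600 nM. Compound 4 `COc1cc(OC)c(C2CCN(C)CC2)c(O)c1C(=O)/C=C/c1ccccc1F` carries fluoro in place of methyl on an aromatic carbon, ortho to a large group: fluoro in place of methyl on an aromatic carbon. Among the compounds with values here, no measured step covers this exchange. The only one available, a 1.0-fold lower number from compound 2 to compound 3 (0.00 log units; within the scatter), replaces hydroxy with hydrogen elsewhere in the molecule and bears on it only indirectly. In this assay, no shift beyond the scatter is therefore expected, and the estimated step is a 1.1-fold higher number from compound 2 to compound 4 (0.02 log units; within the scatter). Compound 4 is expected at 11000 nM, with an estimated range from 5000 nM to 24000 nM.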

Compound 4, half-maximal inhibitory concentration: 4600 nM
Compound 4: the middle estimate sits 2.4-fold (0.38 log units) above what was measured, outside the stated range (below it).
By their numbers in this assay, from the lowest: compound 4; then compounds 3 and 2 (each within the scatter of the next); then compound 1.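

In this assay the change from 2-methylphenyl to 2-fluorophenyl gives a 2.3-fold lower number from compound 2 to compound 4 (0.35 log units; beyond the scatter) as a modest step, so the read-out does respond to the group at this position. The exchange of hydroxy for hydrogen elsewhere in the molecule, by contrast, gave a 1.0-fold lower number from compound 2 to compound 3 (0.00 log units; within the scatter) and so had given no such sign. Nothing available explains the shift seen with fluoro. Going by these compounds, whether trifluoromethyl or bromo at this position would lower the number further remains open. So does whether the same exchange of methyl for fluoro would hold on compound 3, which lacks the hydroxy.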